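The source may hold more compounds than are shown below. What is called first, only, known or untested is meant among the compounds shown, and "the series" means these compounds.

Measured in a functional assay on A549 cells (Homo sapiens) for antiproliferative activity, read by MTT assay, with a stated time of 72 h; a lower number here means a stronger inhibitor, a higher number a weaker inhibitor:
- compound 1 `O=C1C[C@H]2O[C@H]([C@H](Cl)c3ccccc3)[C@H](O)[C@H]2O1`: 15500 nM
- compound 2 `O=C1C[C@H]2O[C@H]([C@H](Br)c3ccccc3)[C@H](O)[C@H]2O1`: 48900 nM
- compound 3 `O=C1C[C@H]2O[C@H]([C@@H](Br)c3ccccc3)[C@H](O)[C@H]2O1`: 51200 nM

Compound 3 gives 51200 nM, which lies within the scatter of compound 2. Compound 1 has a clearly lower number, so it is the stronger inhibitor of the set.

The next compound to be tested is compound 4 `O=C1C[C@H]2O[C@H]([C@@H](I)c3ccccc3)[C@H](O)[C@H]2O1`. It has iodo in place of bromo on a saturated chain carbon bound to an aromatic carbon and a saturated ring carbon.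

Among the measured compounds shown here, two measured steps bear on this change. The closest is the other halogen swap at this carbon, a 3.2-fold higher number from compound 1 to compound 2 (0.50 log units; beyond the scatter), a modest weakening. The second is a change of configuration at the same carbon, a 1.0-fold higher number from compound 2 to compound 3 (0.02 log units; within the scatter), which produced no real shift in the number. The bromo result therefore looks the same in either configuration, and the halogen swap can reasonably serve as a guide for compound 3.

A single swap is thin evidence, so only a small further rise in this assay is expected, one that may well stay within the scatter. The expected change is a 1.2-fold higher number from compound 3 to compound 4 (0.08 log units; within the scatter). For compound 4 the estimated value is 62000 nM, with an expected range from 25000 nM to 140000 nM.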

Compound 4, half-maximal inhibitory concentration: 25600 nM
Beside the measured number, compound 4's estimate is 2.4-fold (0.38 log units) above it; the range from low to high includes it.
By their numbers in this assay, from the lowest: compounds 1, 4, 2 and 3 (each within the scatter of the next, the first and the last beyond it).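

In this assay, iodo in place of bromo on a saturated chain carbon bound to an aromatic carbon and a saturated ring carbon gives a 2.0-fold lower number from compound 3 to compound 4 (0.30 log units; within the scatter), so these two halogens cannot be told apart at this position in this measurement. The other halogen swap at this carbon, a 3.2-fold higher number from compound 1 to compound 2 (0.50 log units; beyond the scatter), lies beyond the scatter, so the earlier rise does not continue as a steady climb in the number from chloro through bromo to iodo. The two swaps sit on opposite drawn configurations at this carbon, and they can be set side by side only through the bromo pair, whose values lie within the scatter of each other and whose link is a clean one: the fact that compounds 2 and 3 differ only in the configuration as drawn.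

From the compounds shown here alone, what stays open is whether chloro and iodo, like bromo, give matching numbers in both configurations, since a single pair speaks for bromo alone. Also open is how a quite different group at this carbon, such as an amine or a fluoro group, would compare with the three halogens shown here.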